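The source may report more compounds than this note shows. Statements on the series, on what has been measured and on what is new or still open speak of the compounds shown alone.

Working notes on the series. In a functional assay on DU-145 cells (Homo sapiens) for inhibition, read by MTT assay, with a stated time of 72 h (on this read-out lower numbers stand for stronger inhibition and higher numbers for weaker inhibition), compound 1 `O=C1C=C(N2CCN(c3ccccc3)CC2)C(=O)c2ccccc21` gives 9900 nM, compound 2 `O=C1C=C(N2CCC(c3ccccc3)CC2)C(=O)c2ccccc21` gives 6000 nM and compound 3 `O=C1C=C(N2CCC(c3ccccc3)CC2)C(=O)c2c(O)cccc21` gives 3000 nM. Compound 2 lies within the scatter of both other compounds.

Compound 4 `Cc1ccccc1C1CCN(C2=CC(=O)c3ccccc3C2=O)CC1` differs from compound 2 in one place: methyl in place of hydrogen on an aromatic carbon, turning phenyl into 2-methylphenyl. Among the measured compounds shown here, the only measured single-place step, a 2.0-fold lower number from compound 2 to compound 3 (0.30 log units; within the scatter), is hydroxy in place of hydrogen on an aromatic carbon. For the measured compounds named here, it involves a different group, and no measured step covers methyl. No step beyond the scatter is therefore expected in this assay, in either direction. The estimated step is a 1.2-fold lower number from compound 2 to compound 4 (0.08 log units; within the scatter). For compound 4 the expected value is 5000 nM, with an estimated range of 2200 nM to 11000 nM.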

Compound 4, half-maximal inhibitory concentration: 6100 nM
Beside the measured number, compound 4's estimate is 1.2-fold (0.09 log units) below it, within the range that was stated.
By their numbers in this assay, from the lowest: compounds 3, 2, 4 and 1 (each within the scatter of the next, the first and the last beyond it).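

In this assay, methyl in place of hydrogen on the phenyl, ortho to a large group, gives a 1.0-fold higher number from compound 2 to compound 4 (0.01 log units; within the scatter), so this change at this position brings no step beyond the scatter. Among the compounds shown here, this is the first reading of a change on the phenyl itself, whereas the earlier step, a 2.0-fold lower number from compound 2 to compound 3 (0.30 log units; within the scatter), concerns hydroxy on an aromatic carbon of the shared core. No supporting measurement bears on this result.

As far as these compounds go, whether an amine or a carboxylic acid at this position would give a step beyond the scatter stays open, as does the outcome for methyl elsewhere on the phenyl.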